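Methoxy in Place of Fluoro Among Three Compounds at the Limit

This account rests on a few compounds, and the source may have more. Where it says the series, first, only, none or still open, it means among the compounds named here.

Compound 3 `N#CC1=C(N)Oc2c(N)cc3nc4ccccc4nc3c2C12C(=O)N(Cc1cnnn1-c1ccc(F)cc1)c1ccccc12` stands where every measured compound in this set stands. In an ADME assay on HUVEC cells (Homo sapiens) for antiproliferative activity, read by MTT assay, with a stated time of 48 h (on this read-out higher numbers stand for weaker inhibition and lower numbers for stronger inhibition), compound 3 gives > 50000 nM, which is a limit of the assay and not a number. Compound 1 `N#CC1=C(N)Oc2c(c3nc4ccccc4nc3c3ccccc23)C12C(=O)N(Cc1cnnn1-c1ccc(F)cc1)c1ccccc12` is in the same position: in this assay compound 1 gives > 50000 nM, again a limit. Compound 2 `COc1ccc(-n2nncc2CN2C(=O)C3(C(C#N)=C(N)Oc4c3c3nc5ccccc5nc3c3ccccc43)c3ccccc32)cc1` completes the picture: in this assay compound 2 gives > 50000 nM, also a limit. All three values thus sit at the limit of > 50000 nM in this assay, at which 3 of the 3 values shown sit, so nothing separates the three compounds on the numbers shown.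

Compound 4 `COc1ccc(-n2nncc2CN2C(=O)C3(C(C#N)=C(N)Oc4c(N)cc5nc6ccccc6nc5c43)c3ccccc32)cc1` differs from compound 3 by methoxy in place of fluoro on an aromatic carbon. For the measured compounds named here, the one measured step that bears on this change is a step that the two limits leave unreadable from compound 1 to compound 2; because both of its ends are limits, its size cannot be read, and it gives no sign that the swap moves a compound into the measurable range. From this, the step that the limit leaves unreadable from compound 3 to compound 4 is expected to show no change beyond the scatter, with compound 4 most likely staying at the limit. The estimate for compound 4 in this assay is therefore 60000 nM, with an expected range from 20000 nM to 200000 nM.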

Compound 4, half-maximal inhibitory concentration: > 50000 nM
Compound 4 was reported as a limit; the forecaster's own chance of this, stated with the estimate: 85%; the middle value does not contradict the limit.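

For the compounds shown here, compound 3 and compound 4 both stand at a limit of the assay in this assay and not at a number, so no step between them can be read: the limit of > 50000 nM in this assay, at which 4 of the 4 values shown sit.

The compounds shown leave open whether methoxy in place of fluoro changes anything in this assay at all, and what would bring a compound of this set into the measurable range.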